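A few compounds are considered here, and "the series" means these few. Any claim that something is new, unique, unknown or untested is made for them only; others in the source may bear on it.

Measured compounds:
compound 1 `Fc1ccc(-n2c(S)nnc2Sc2nnc(-c3ccccc3)n2-c2ccccc2)cc1` — in a functional assay on HT-29 cells (Homo sapiens) for inhibition, read by MTT assay, with a stated time of 48 h (on this read-out higher numbers stand for weaker inhibition and lower numbers for stronger inhibition), compound 1 gives 32800 nM
compound 2 `Sc1nnc(Sc2nnc(-c3ccccc3)n2-c2ccccc2)n1-c1ccccc1` — in this assay compound 2 gives 28300 nM

Going by the values given here, compound 2 holds the lowest of the two numbers in this assay, but its nearest neighbour is compound 1, and the only measured step, a 1.2-fold lower number from compound 1 to compound 2 (0.06 log units; within the scatter), lies within the scatter, so the two values cannot be told apart.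

Compound 3 `Sc1nnc(Sc2nnc(-c3ccccc3)n2-c2ccccc2)n1-c1ccc(Cl)cc1` is not yet measured. It differs from compound 2 by chloro in place of hydrogen on an aromatic carbon. Among the compounds with values here, the one measured step that bears on this change, a 1.2-fold lower number from compound 1 to compound 2 (0.06 log units; within the scatter), also concerns a halogen on the same kind of ring and was within the scatter. No step beyond the scatter is therefore expected in this assay for compound 3, in either direction.

For compound 3 the expected step is a 1.1-fold higher number from compound 2 to compound 3 (0.03 log units; within the scatter). For compound 3 the estimate in this assay is 30000 nM, with a range from 14000 nM to 65000 nM.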

Compound 3, half-maximal inhibitory concentration: 38400 nM
Estimate against measurement, compound 3: 1.3-fold (0.11 log units) below; the measured number falls inside the stated range.
By their numbers in this assay, from the lowest: compounds 2, 1 and 3 (each within the scatter of the next).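

In this assay, the change from phenyl to 4-chlorophenyl gives a 1.4-fold higher number from compound 2 to compound 3 (0.13 log units; within the scatter), and exchanging fluoro for chloro at the same place gives a 1.2-fold higher number from compound 1 to compound 3 (0.07 log units; within the scatter). Chloro thus joins fluoro as a second halogen at this place, para to a large group, and neither halogen has yet produced a step beyond the scatter from the unsubstituted phenyl of compound 2. Nothing available bears on why these three compounds remain so close.

Going by these compounds, it remains open whether an amine, a carboxylic acid or a longer chain at this place would give a step beyond the scatter. Also open, on these data alone, is whether a change on the other phenyl groups of the shared core would do so.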